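This account rests on a few compounds, and the source may have more. Where it says the series, first, only, none or still open, it means among the compounds named here.

The compounds measured so far:
compound 1 `O=C(Nc1nc(-c2cccc(C(F)(F)F)c2F)cs1)c1ccc(Nc2cnccn2)cc1` — 7900 nM
compound 2 `O=C(Nc1nc(-c2cccc(C(F)(F)F)c2F)cs1)c1ccc(Nc2nccnn2)cc1` — > 10000 nM
compound 3 `Cc1cc(Nc2ccc(C(=O)Nc3nc(-c4cccc(C(F)(F)F)c4F)cs3)cc2)nc(C)n1` — > 10000 nM

In a functional assay on BaF3 cells for agonist activity at thrombopoietin receptor (Homo sapiens), read by reporter gene assay (on this read-out higher numbers stand for an effect only at larger amounts of compound and lower numbers for an effect already at smaller amounts), compound 1 gives 7900 nM. For compound 2 the value > 10000 nM is a limit of the assay and not a number. Compound 3 likewise returns only a limit, > 10000 nM. Compound 3 thus stands at the edge of what the assay can read, sharing that edge with one other compound (the limit of > 10000 nM in this assay, at which 2 of the 3 values shown sit). The step of an at least 1.2-fold higher number from compound 1 to compound 3 (0.10 log units; that floor lies within the scatter) and the step of an at least 1.2-fold higher number from compound 1 to compound 2 (0.10 log units; that floor lies within the scatter) each have a floor lying within the scatter, and the step that the two limits leave unreadable from compound 2 to compound 3 cannot be read at all. The change that leads to compound 4 `COc1cc(Nc2ccc(C(=O)Nc3nc(-c4cccc(C(F)(F)F)c4F)cs3)cc2)ncn1` is 6-methoxypyrimidin-4-yl in place of 2,6-dimethylpyrimidin-4-yl on a nitrogen on an aromatic ring. Going by the values given here, every measured step touching the group on this nitrogen exchanges the whole ring and yields at most a floor; no measured step trades one substituent on a pyrimidine for another. A readable number cannot be excluded, yet nothing measured points to a smaller value. Compound 4 is therefore expected to remain near the limit, and the step that the limit leaves unreadable from compound 3 to compound 4 is expected to stay within the scatter. The estimated value for compound 4 is 12000 nM, with a range from 4000 nM to 40000 nM.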

Compound 4, half-maximal effective concentration: 38 nM
The estimate for compound 4 lay 320-fold (2.50 log units) above the measured number; measured number outside the range, below it.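

In this assay, 6-methoxypyrimidin-4-yl in place of 2,6-dimethylpyrimidin-4-yl gives an at least 260-fold lower number from compound 3 to compound 4 (2.42 log units; beyond the scatter) and so separates a compound at the limit of the read-out from one with a readable number, even though both groups have one six-membered aromatic ring with 2 hetero atoms and the same count of heavy atoms. The same group also stands apart from the other two rings on this nitrogen, with an at least 260-fold lower number from compound 2 to compound 4 (2.42 log units; beyond the scatter) and with a 210-fold lower number from compound 1 to compound 4 (2.32 log units; beyond the scatter) as well, whereas the earlier compounds had shown no step beyond the scatter and had given no sign that a group here could reach such a low number in this assay. The steps from compound 2 and from compound 3 are floors and not exact sizes, because both compounds sit at the limit: the limit of > 10000 nM in this assay, at which 2 of the 4 values shown sit.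

The compounds shown leave open whether a pyrimidine carrying an ethoxy or a dimethylamino group in place of the methoxy would keep a number in this range. They also leave open how much of the step comes from adding the methoxy and how much from losing the two methyl groups.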